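This account rests on a few compounds, and the source may have more. Where it says the series, first, only, none or still open, it means among the compounds named here.

Measured compounds:
compound 1 `CC[C@H](C)[C@H](N)CN(C(=O)[C@@H]1C[C@H]1c1ccccc1Cl)c1ccc(-c2ccccc2)cc1`: > 25000 nM
compound 2 `CC(C)C[C@H](N)CN(C(=O)[C@@H]1C[C@H]1c1ccccc1)c1ccc(-c2ccsc2)cc1`: 1200 nM

In a functional assay for agonist activity at G protein-coupled receptor 88 (Homo sapiens), read by HTRF and cAMP accumulation (a lower number here means that less compound is needed, a higher number that more compound is needed for the effect), compound 1 gives > 25000 nM, which is a limit of the assay rather than a number. For the measured compounds named here, compound 2 gives 1200 nM in this assay and is the only compound with a number here, since (the limit of > 25000 nM in this assay, at which 1 of the 2 values shown sits). Compound 3 `COc1ccc(-c2ccc(N(C[C@@H](N)CC(C)C)C(=O)[C@@H]3C[C@H]3c3ccccc3)cc2)cc1` differs from compound 2 by 4-methoxyphenyl in place of thiophen-3-yl on an aromatic carbon. Going by the values given here, no measured pair shows this kind of change, so the step from compound 2 to compound 3 is expected to be small, at a 1.5-fold lower number from compound 2 to compound 3 (0.18 log units; within the scatter), within the usual scatter. Compound 3 is therefore estimated at 800 nM, with a range from 250 nM to 2500 nM.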

Compound 3, half-maximal effective concentration: 330 nM
The estimate for compound 3 lay 2.4-fold (0.38 log units) above the measured number, within the range that was stated.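

In this assay this position, on an aromatic carbon para to a large group, now has a step that can be read: 4-methoxyphenyl in place of thiophen-3-yl gives a 3.6-fold lower number from compound 2 to compound 3 (0.56 log units; beyond the scatter). The earlier compounds shown here could not show this, since they differ in more than one place. Nothing measured here explains the change. Still open, going by these compounds, is whether the lower number belongs to the six-membered ring or to its methoxy group, and how a phenyl ring carrying an amine or a carboxylic acid would read at this position.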